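Swapping the Benzyl Ring Toward an Amino-Methoxy Pattern

The compounds below may be only part of what the source reports. "The series", "measured", "known", "first", "only" and "open" are said of these compounds alone.

Three measured compounds share one core. Compound 1 `COc1cc(N(Cc2ccc(F)cc2)C(=O)CSc2nc3ccccc3s2)cc(OC)c1OC` gives in a functional assay on MGC-803 cells (Homo sapiens) for antiproliferative activity, read by MTT assay, with a stated time of 48 h (a lower number here means a stronger inhibitor, a higher number a weaker inhibitor), only a limit of the assay, > 80000 nM. Compound 2 `COc1ccc(CN(C(=O)CSc2nc3ccccc3s2)c2cc(OC)c(OC)c(OC)c2)cc1O` gives 35 nM in this assay, and compound 3 `COc1cc(N(Cc2ccc(C)cc2)C(=O)CSc2nc3ccccc3s2)cc(OC)c1OC` gives 54200 nM. Compound 3 thus holds the highest of the two numbers, the gap being a 1500-fold higher number from compound 2 to compound 3 (3.19 log units; beyond the scatter). Compound 4 `COc1ccc(CN(C(=O)CSc2nc3ccccc3s2)c2cc(OC)c(OC)c(OC)c2)cc1N` differs from compound 3 in one place: 3-amino-4-methoxyphenyl in place of 4-methylphenyl on a saturated chain carbon bound to an amide-type nitrogen. The comparable move, 3-hydroxy-4-methoxyphenyl in place of 4-fluorophenyl, was an at least 2200-fold lower number from compound 1 to compound 2 (3.35 log units; beyond the scatter), and the change toward compound 4 brings the related 3-amino-4-methoxyphenyl, so a large drop in number is expected, in the direction of stronger inhibition. Compound 4 is estimated at 100 nM with a range of 20 nM to 1000 nM, an expected step of a 540-fold lower number from compound 3 to compound 4 (2.73 log units; beyond the scatter).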

Compound 4, half-maximal inhibitory concentration: 84 nM
Compound 4: middle estimate off by 1.2-fold (0.08 log units), on the high side; the range from low to high includes it.
By their numbers in this assay, from the lowest: compound 2; then compound 4; then compound 3. At a limit, above all of these: compound 1.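

With the 3-amino-4-methoxyphenyl group at this place, there is a 650-fold lower number from compound 3 to compound 4 (2.81 log units; beyond the scatter), so among these compounds the large drop does not depend on the hydroxy group of compound 2. Amino in place of hydroxy matters far less, though it is still a real change: a 2.4-fold higher number from compound 2 to compound 4 (0.38 log units; beyond the scatter). The remaining step, an at least 950-fold lower number from compound 1 to compound 4 (2.97 log units; beyond the scatter), is only a floor set by a limit of the assay: the limit of > 80000 nM in this assay, at which 1 of the 4 values shown sits.

Still open, as far as these compounds go, is whether a methylamino or acetamido group could stand in for the amino group. Whether an ethoxy group could replace the methoxy group is also unknown.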